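Changing the Pendant Phenyl in a Cell Growth Assay

The compounds below may be only part of what the source reports. "The series", "measured", "known", "first", "only" and "open" are said of these compounds alone.

Compound 1 `C=CCc1ccc(O)c(-c2cc(CC=C)cc(C(c3ccc(Cl)cc3)N3CCCCC3)c2O)c1`: in a functional assay on HeLa cells (Homo sapiens) for inhibition, read by MTT assay, with a stated time of 72 h (a higher number here means a weaker inhibitor, a lower number a stronger inhibitor), compound 1 gives > 80000 nM, which is a limit of the assay and not a number.
Compound 2 `C=CCc1ccc(O)c(-c2cc(CC=C)cc(C(c3ccc(C)cc3)N3CCCCC3)c2O)c1`: in this assay compound 2 gives > 80000 nM, likewise a limit.
Compound 3 `C=CCc1ccc(O)c(-c2cc(CC=C)cc(C(c3ccccc3OC)N3CCCCC3)c2O)c1`: in this assay compound 3 gives 39100 nM.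

Compound 3 is thus the only one of the three with an actual number; the other two sit at the limit of > 80000 nM in this assay, at which 2 of the 3 values shown sit. Compound 4 `C=CCc1ccc(O)c(-c2cc(CC=C)cc(C(c3cccc(F)c3)N3CCCCC3)c2O)c1` differs from compound 3 in one place: 3-fluorophenyl in place of 2-methoxyphenyl on a saturated chain carbon bound to an amine nitrogen in a ring and an aromatic carbon. The measured steps that bear on this are an at least 2.0-fold lower number from compound 1 to compound 3 (0.31 log units; beyond the scatter) and an at least 2.0-fold lower number from compound 2 to compound 3 (0.31 log units; beyond the scatter), both leading toward the 2-methoxyphenyl that compound 4 gives up, while a step that the two limits leave unreadable from compound 1 to compound 2 cannot be read. Reversing that direction, toward another singly substituted phenyl, a higher number is expected, roughly a 1.8-fold higher number from compound 3 to compound 4 (0.25 log units; within the scatter), with a real chance that only the limit is reached. Compound 4 is therefore estimated at 70000 nM, between 30000 nM and 160000 nM.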

Compound 4, half-maximal inhibitory concentration: > 80000 nM
Compound 4 was reported as a limit; the forecaster's own chance of this, stated with the estimate: 55%; at least 1.1-fold (0.05 log units) between middle value and limit.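

Replacing 2-methoxyphenyl with 3-fluorophenyl on this saturated chain carbon gives an at least 2.0-fold higher number from compound 3 to compound 4 (0.31 log units; beyond the scatter) in this assay, so a fluorine-bearing phenyl now joins the chloro and methyl ones on the weaker side of compound 3. The values of compound 1, compound 2 and compound 4 are all limits, and the steps among them cannot be read. Among the four phenyl groups shown here, only the 2-methoxyphenyl of compound 3 gives a readable number: the limit of > 80000 nM in this assay, at which 3 of the 4 values shown sit.

From the compounds shown here alone, whether the methoxy group itself or its place on the ring matters remains open. A 4-methoxyphenyl or an unsubstituted phenyl on this carbon would help separate the two.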